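The source may hold more compounds than are shown below. What is called first, only, known or untested is meant among the compounds shown, and "the series" means these compounds.

The measured compounds:

Compound 1 `OC[C@H]1O[C@@H](n2cnc3c(SCCCc4ccccc4)ncnc32)[C@H](O)[C@@H]1O` — 1350 nM
Compound 2 `CCCC(C)n1cnc2c(SCc3ccccn3)nc(N)nc21` — 41700 nM
Compound 3 `OC[C@H]1O[C@@H](n2cnc3c(CSc4ccccc4Br)ncnc32)[C@H](O)[C@@H]1O` — 2400 nM

These three compounds were characterised in an assay on isolated protein for binding affinity to Equilibrative nucleoside transporter 1 (Homo sapiens); a lower number here means a stronger inhibitor, a higher number a weaker inhibitor. Compound 3 sits in the middle of the three numbers. Its value and that of compound 1 lie within the scatter of each other, so the two cannot be told apart on the numbers. Compound 2, by contrast, gives a clearly higher number than compound 3, a gap that goes beyond the scatter.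

Compound 4 `OC[C@H]1O[C@@H](n2cnc3c(CSc4ccc(F)cc4)ncnc32)[C@H](O)[C@@H]1O` has not yet been measured in this assay. It differs from compound 3 in one place: 4-fluorophenyl in place of 2-bromophenyl on a sulfur. The two groups are of the same size and carry the same counts of donors and acceptors. Within the data shown here, no pair of measured compounds shows the effect of this kind of exchange, so nothing in the data points to a large shift in either direction. The step from compound 3 is expected to stay within the scatter, as a 1.3-fold higher number from compound 3 to compound 4 (0.10 log units; within the scatter) expresses. The estimate for compound 4 is therefore 3000 nM, with a range from 1000 nM to 9000 nM.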

Compound 4, half-maximal inhibitory concentration: 158 nM
For compound 4 the middle estimate is 19-fold (1.28 log units) above the measured one; measured number below the stated range.
By their numbers in this assay, from the lowest: compound 4; then compounds 1 and 3 (each within the scatter of the next); then compound 2.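

In this assay, 4-fluorophenyl in place of 2-bromophenyl on a sulfur gives a 15-fold lower number from compound 3 to compound 4 (1.18 log units; beyond the scatter) and counts as a large step. The earlier compounds shown here did not show that this position responds so strongly to the aryl group on the sulfur, and here it does so although both groups have the same heavy-atom count, the same six-membered aromatic ring of carbon only, and no hydrogen-bond donors or acceptors. Nothing in the available data bears on the reason for this step.

The exchange alters both the halogen and its place on the ring, so the step cannot be assigned to either one alone. On these data alone, a 4-bromophenyl or 2-fluorophenyl group on this sulfur would separate the two, and how a plain phenyl group would compare also remains open.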